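Swapping one phenyl group: compound 3 to compound 4

The compounds below may be only part of what the source reports. "The series", "measured", "known", "first", "only" and "open" are said of these compounds alone.

compound 1 `COc1cc(NC(=O)Nc2cccc3c(Nc4cc(OC)cc(OC)c4)ncnc23)cc(OC)c1`: 366 nM
compound 2 `COc1cc(Nc2ncnc3c(NC(=O)Nc4ccc(C)cc4C)cccc23)cc(OC)c1`: 1290 nM
compound 3 `COc1cc(Nc2ncnc3c(NC(=O)Nc4ccc(F)cc4C(F)(F)F)cccc23)cc(OC)c1`: 2970 nM

All three compounds were tested in a functional assay on RT-112 cells (Homo sapiens) for antiproliferative activity, read by MTT assay, with a stated time of 72 h; a lower number here means a stronger inhibitor of growth, a higher number a weaker inhibitor of growth. Compound 3, at 2970 nM, has the highest number of the three, which makes it the weakest growth inhibitor among them.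

Compound 4 `COc1cc(Nc2ncnc3c(NC(=O)Nc4ccc([N+](=O)[O-])cc4)cccc23)cc(OC)c1` has not yet been measured. It keeps the shared core and differs from compound 3 in one place, on an amide-type nitrogen: 4-nitrophenyl in place of 4-fluoro-2-(trifluoromethyl)phenyl on an amide-type nitrogen. Put simply, 4-nitrophenyl stands in place of 4-fluoro-2-(trifluoromethyl)phenyl.

The measured steps that bear on this change are the ones that swap the group at this same place. They are a 2.3-fold higher number from compound 2 to compound 3 (0.36 log units; beyond the scatter), a 3.5-fold higher number from compound 1 to compound 2 (0.55 log units; beyond the scatter) and an 8.1-fold higher number from compound 1 to compound 3 (0.91 log units; beyond the scatter). Each is modest but beyond the scatter, so this group does matter. Within the data shown here, none of the measured compounds carries 4-nitrophenyl, however, so the data give no direct guide to it. Compound 3 sits at the top of this small range, so a modest move towards a lower number is expected, though a move the other way remains possible. The estimated step is a 2.5-fold lower number from compound 3 to compound 4 (0.39 log units; beyond the scatter). For compound 4 the estimate is 1200 nM, with an expected range from 400 nM to 3600 nM.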

Compound 4, concentration for 50% growth inhibition: > 20000 nM
Compound 4: a limit, no number (the forecaster's own chance of this, stated with the estimate: 5%); middle value at least 16-fold (1.22 log units) away from the limit.
By their numbers in this assay, from the lowest: compound 1; then compound 2; then compound 3. At a limit, above all of these: compound 4.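

In this assay, compound 4 gives a limit and not a number: the limit of > 20000 nM in this assay, at which 1 of the 4 values shown sits.

Against the three measured compounds, the 4-nitrophenyl group gives an at least 6.7-fold higher number from compound 3 to compound 4 (0.82 log units; beyond the scatter), an at least 15-fold higher number from compound 2 to compound 4 (1.19 log units; beyond the scatter) and an at least 54-fold higher number from compound 1 to compound 4 (1.73 log units; beyond the scatter). The earlier groups on this amide-type nitrogen all gave measurable numbers and differed from each other by modest steps, so this result adds something new: a single change of the phenyl group at this place can take a compound past the limit of the assay.

This one change removes the fluorine and the trifluoromethyl group and brings in the nitro group, so the compounds shown cannot tell whether the nitro group itself or the loss of the other two groups matters more; plain phenyl, 4-aminophenyl or 4-cyanophenyl at this place would help to separate these. As far as these compounds go, how far compound 4 lies past its limit also stays open, and with it the full size of each of its steps.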